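Same Ring Swap, Tested on a Different Core

The source may report more compounds than this note shows. Statements on the series, on what has been measured and on what is new or still open speak of the compounds shown alone.

Measured so far:
Compound 1, `O=c1c(CSC(=S)N2CCCCC2)coc2cc(Cl)ccc12`, in a functional assay on MCF7 cells (Homo sapiens) for antiproliferative activity, read by MTT assay, with a stated time of 72 h (on this read-out lower numbers stand for stronger inhibition and higher numbers for weaker inhibition), gives 380 nM.
Compound 2, `O=c1c(CSC(=S)N2CCCC2)coc2cc(Cl)ccc12`, in this assay gives 600 nM.
Compound 3, `CCOC(=O)c1cc(=O)c2cc(CSC(=S)N3CCCC3)ccc2o1`, in this assay gives only an assay limit, > 25000 nM.

Compounds 1 and 2 share a core and differ by piperidin-1-yl in place of pyrrolidin-1-yl on a thiocarbonyl carbon. That change gives a 1.6-fold lower number from compound 2 to compound 1 (0.20 log units; within the scatter), so the two compounds cannot be told apart on this read-out. Compound 3 carries a different core; how its core differs from that of compound 2 is not broken down here. Its result is a limit rather than a number, the point described by the limit of > 25000 nM in this assay, at which 1 of the 3 values shown sits.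

Compound 4, `CCOC(=O)c1cc(=O)c2cc(CSC(=S)N3CCCCC3)ccc2o1`, is not yet measured. It differs from compound 3 by piperidin-1-yl in place of pyrrolidin-1-yl on a thiocarbonyl carbon, the same change as between compound 2 and compound 1. For compound 4 the step of a number no higher from compound 3 to compound 4 (the limit leaves the size open) is expected, because a 1.6-fold lower number from compound 2 to compound 1 (0.20 log units; within the scatter) was small and because compound 3 sits at the limit (the limit of > 25000 nM in this assay, at which 1 of the 3 values shown sits). Compound 4 is therefore estimated at 25000 nM in this assay, most likely again reported only as a limit, with a range of 8000 nM to 60000 nM.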

Compound 4, half-maximal inhibitory concentration: 21900 nM
Estimate against measurement, compound 4: 1.1-fold (0.06 log units) above, and the stated range covers the measured number.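

On these data alone, on the second core, piperidin-1-yl in place of pyrrolidin-1-yl gives an at least 1.1-fold lower number from compound 3 to compound 4 (0.05 log units; that floor lies within the scatter), and this figure is only a floor, so the full size of the step stays open. In this assay compound 3 is reported only as a limit, > 25000 nM. The swap therefore shows no sign of acting differently on the two cores, but this does not prove that it carries over unchanged: the same change on two cores in this assay, a 1.6-fold lower number (0.20 log units; within the scatter) from compound 2 to compound 1 and an at least 1.1-fold lower number (0.05 log units; that floor lies within the scatter) from compound 3 to compound 4; the limit leaves it open whether they differ

The compounds shown leave open whether a different group on the thiocarbonyl carbon, such as a morpholine ring or an open-chain diethylamine, would shift the number further on either core. They also leave open how the same swap would behave on a core carrying a carboxylic acid in place of the ethyl ester.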